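This account rests on a few compounds, and the source may have more. Where it says the series, first, only, none or still open, it means among the compounds named here.

Compound 1 `O=c1[nH]c(=O)n([C@H]2C[C@H](O)[C@@H](CO)O2)cc1[N+](=O)[O-]` is the reference point of this small set. In an ADME assay on L1210/0 cells (Mus musculus) for cytotoxicity, with a stated time of 48 h (a higher number here means a weaker inhibitor, a lower number a stronger inhibitor), compound 1 gives 130 nM. Compound 2 `O=c1[nH]c(=O)n([C@H]2C[C@H](O)[C@@H](CO)O2)cc1C#CCCO` carries a 4-hydroxybut-1-yn-1-yl group where compound 1 carries nitro. In this assay compound 2 reaches only a limit, > 200000 nM. The step of an at least 1500-fold higher number from compound 1 to compound 2 (3.18 log units; beyond the scatter) is therefore large. Compound 3 `O=c1[nH]c(=O)n([C@H]2C[C@H](O)[C@@H](CO)O2)cc1/C=C/Cl` carries 2-chloroethenyl in that same place. In this assay compound 3 likewise reaches only a limit, > 200000 nM. The step of an at least 1500-fold higher number from compound 1 to compound 3 (3.18 log units; beyond the scatter) matches the previous one. Compound 3 thus stands at the weak end of the numbers shown, sharing the limit of > 200000 nM in this assay, at which 2 of the 3 values shown sit, with compound 2, so the step that the two limits leave unreadable from compound 2 to compound 3 cannot be read.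

Compound 4 `CC(C)(C)C#Cc1cn([C@H]2C[C@H](O)[C@@H](CO)O2)c(=O)[nH]c1=O` is not yet measured. It differs from compound 3 by 3,3-dimethylbut-1-yn-1-yl in place of 2-chloroethenyl on an aromatic carbon. The step that bears most directly on it, from compound 2 to compound 3, is unreadable, and both steps from compound 1 ran up to the limit. Compound 2, which also has a triple bond in this position, sits at the limit > 200000 nM. No step beyond the scatter is therefore expected in this assay, in either direction. Compound 4 is expected to give 200000 nM, within a range from 40000 nM to 1000000 nM, and the expected step is a number no higher from compound 3 to compound 4 (the limit leaves the size open).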

Compound 4, half-maximal inhibitory concentration: > 200000 nM
Compound 4 ended at the assay's limit; the forecaster's own chance of this, stated with the estimate: 75%; the middle value sits exactly at the limit.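

Replacing nitro with 3,3-dimethylbut-1-yn-1-yl gives an at least 1500-fold higher number from compound 1 to compound 4 (3.18 log units; beyond the scatter), so a third group on this aromatic carbon now loses the cytotoxicity that compound 1 shows in this assay. Compound 4 also shows that placing tert-butyl instead of 2-hydroxyethyl on the triple-bonded carbon does not bring the number back into a readable range, as the value for compound 4 is only a limit. Compound 1 is now the one exception among the compounds shown, with compounds 2, 3 and 4 sharing one ceiling: the limit of > 200000 nM in this assay, at which 3 of the 4 values shown sit.

Because all three compounds sit at that limit, the steps among them cannot be read, and any real differences in strength between them stay hidden. The compounds shown also leave open whether nitro is unusual in keeping the cytotoxicity or whether another group on this carbon, such as an amine, a nitrile or a plain methyl, would give a readable value as well.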